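The source may report more compounds than this note shows. Statements on the series, on what has been measured and on what is new or still open speak of the compounds shown alone.

Measured in a functional assay on MCF7 cells (Homo sapiens) for antiproliferative activity, read by sulforhodamine B assay, with a stated time of 48 h; on this read-out lower numbers stand for stronger inhibition and higher numbers for weaker inhibition:
- Compound 1 `Cc1cccc(OS(=O)(=O)c2ccc(N3CCN(C)C3=O)cc2)c1`: 5100 nM
- Compound 2 `CN1CCN(c2ccc(S(=O)(=O)Oc3ccc(Cl)cc3)cc2)C1=O`: > 100000 nM

The entry for compound 2 is a limit of the assay and not a number. For the measured compounds named here, compound 1 therefore holds the only true number so far, 5100 nM, and no ranking of potency can be built around it.

The next compound is compound 3 `CCCN1CCN(c2ccc(S(=O)(=O)Oc3cccc(C)c3)cc2)C1=O`. It keeps the core of compound 1 and differs by ethyl in place of hydrogen on a saturated chain carbon bound to an amide-type nitrogen in a ring. Cut one bond further out, the same difference reads methyl to propyl.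

Going by the values given here, only one measured step exists, an at least 19-fold higher number from compound 1 to compound 2 (1.29 log units; beyond the scatter), and it is large. That step is 4-chlorophenyl in place of 3-methylphenyl on an oxygen, which is a different change at a different place. It shows that the number in this assay can move far within this pair, but it gives no direct measure for a longer chain. Among the compounds with values here, with only that step as a guide, a small shift towards a higher number is expected, with wide uncertainty in either direction. The estimated change is a 1.4-fold higher number from compound 1 to compound 3 (0.14 log units; within the scatter). Compound 3 is expected at 7000 nM, with an estimated range of 1500 nM to 40000 nM.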

Compound 3, half-maximal inhibitory concentration: 86000 nM
Estimate against measurement, compound 3: 12-fold (1.09 log units) below; measured number above the stated range.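

In this assay, the place on the amide-type nitrogen in a ring turns out to matter: lengthening methyl to propyl gives a 17-fold higher number from compound 1 to compound 3 (1.23 log units; beyond the scatter). The earlier compounds had shown a large move only for a change to the group on the oxygen, so this is the first sign that a second part of the molecule can also shift the number, and here a simple carbon chain is enough to do it. Any further rise from changes at this place could soon run into the end of the scale: the limit of > 100000 nM in this assay, at which 1 of the 3 values shown sits.

Two chain lengths cannot show whether the number climbs steadily with length or jumps at one point, so an ethyl group or a butyl group at this place would be needed to draw that curve. As far as these compounds go, it also stays open whether the trend reverses with a plain hydrogen on that nitrogen, or whether a chain ending in an amine or a carboxylic acid behaves like propyl or brings the number back down.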